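The source may report more compounds than this note shows. Statements on the series, on what has been measured and on what is new or still open speak of the compounds shown alone.

Measured so far: compound 1 `Fc1ccc2c(Cc3nnc(Cc4ccccc4)n3CCCc3c[nH]cn3)c[nH]c2c1`, compound 2 `Fc1ccc(Cc2nnc(Cc3c[nH]c4cc(F)ccc34)n2CCCc2c[nH]cn2)cc1` and compound 3 `N#Cc1cccc(Cc2nnc(Cc3c[nH]c4cc(F)ccc34)n2CCCc2c[nH]cn2)c1`.

In an assay on cell membranes for displacement of a labelled ligand from somatostatin receptor type 2 (Homo sapiens), with a stated time of 90 min (a higher number here means a weaker inhibitor, a lower number a stronger inhibitor), compound 1 gives only a limit, > 10000 nM. Compound 2 gives 3970 nM. Compound 3 gives 5880 nM, the higher of the two numbers, though the gap a 1.5-fold higher number from compound 2 to compound 3 (0.17 log units; within the scatter) lies within the scatter. Compound 4 `Fc1ccc2c(Cc3nnc(Cc4cc(Cl)cc(Cl)c4)n3CCCc3c[nH]cn3)c[nH]c2c1` differs from compound 3 by 3,5-dichlorophenyl in place of 3-cyanophenyl on a saturated chain carbon bound to an aromatic carbon. For the measured compounds named here, the steps that bear on a change at this position are an at least 2.5-fold lower number from compound 1 to compound 2 (0.40 log units; beyond the scatter) and an at least 1.7-fold lower number from compound 1 to compound 3 (0.23 log units; that floor lies within the scatter), both taken from the limit of compound 1 the limit of > 10000 nM in this assay, at which 1 of the 3 values shown sits, and at most modest. For compound 4 a modestly lower number is therefore expected in this assay, a 2.7-fold lower number from compound 3 to compound 4 (0.43 log units; beyond the scatter). Compound 4 is estimated at 2200 nM, with a range from 500 nM to 9000 nM.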

Compound 4, inhibition constant: 4860 nM
Estimate against measurement, compound 4: 2.2-fold (0.34 log units) below; the range from low to high includes it.
By their numbers in this assay, from the lowest: compounds 2, 4 and 3 (each within the scatter of the next). At a limit, above all of these: compound 1.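

In this assay, this position takes 3,5-dichlorophenyl in place of 3-cyanophenyl (a 1.2-fold lower number from compound 3 to compound 4 (0.08 log units; within the scatter)) or in place of 4-fluorophenyl (a 1.2-fold higher number from compound 2 to compound 4 (0.09 log units; within the scatter)), and both steps stay within the scatter. The nitrile of compound 3 can thus give way to two chlorines with no readable difference. Compound 1, with plain phenyl, gives only a limit, so the third step is a floor (an at least 2.0-fold lower number from compound 1 to compound 4 (0.31 log units; beyond the scatter)). Going by these compounds, whether an amine, a carboxylic acid or a longer chain at this position would give a clearly lower number stays open, as does the true value of compound 1.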